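Bromo to phenyl on the aryl ketone of compound 1

The source may hold more compounds than are shown below. What is called first, only, known or untested is meant among the compounds shown, and "the series" means these compounds.

Compound 1 `CC(=O)c1ccc(Nc2ccnc(SCC(=O)c3ccc(Br)cc3)n2)cc1` in a functional assay on NCI-H23 cells (Homo sapiens) for inhibition, read by sulforhodamine B assay, with a stated time of 48 h, tested at 10 uM (on this read-out lower numbers stand for less inhibition of growth and higher numbers for more inhibition of growth at the one concentration tested), gives 16%, the middle of three values that all lie within the scatter of one another. Compound 2 `CCOC(=O)c1ccc(Nc2ccnc(SCC(=O)c3ccc([N+](=O)[O-])cc3)n2)cc1` gives 13% and compound 3 `CCOC(=O)c1ccc(Nc2ccnc(SCC(=O)c3ccc(C#N)cc3)n2)cc1` gives 20% in this assay. Going by the values given here, the one step in the set, a number 7 percentage points higher from compound 2 to compound 3 (within the scatter), is within the scatter. Compound 4 `CC(=O)c1ccc(Nc2ccnc(SCC(=O)c3ccc(-c4ccccc4)cc3)n2)cc1` carries the change (phenyl in place of bromo on an aromatic carbon). Among the compounds with values here, no measured step swaps bromo for phenyl; the only step available changes the group on the same aromatic carbon and stays within the scatter, so no step beyond the scatter is expected in this assay. The expected step is a number 2 percentage points higher from compound 1 to compound 4 (within the scatter). Compound 4 is estimated at 18%, range 5% to 35%.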

Compound 4, percent growth inhibition at one concentration: 10%
For compound 4 the middle estimate is 8 percentage points above the measured one; measured number inside the range.
By their numbers in this assay, from the lowest: compounds 4, 2, 1 and 3 (each within the scatter of the next).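

Phenyl in place of bromo on the aromatic carbon gives a number 6 percentage points lower from compound 1 to compound 4 (within the scatter) in this assay. This place therefore accepts an added six-membered aromatic ring of carbon only without a step beyond the scatter, whereas the earlier step covered only the exchange of nitro for cyano. Nothing available explains this tolerance.

Going by these compounds, whether an amine or a carboxylic acid on this carbon would give a step beyond the scatter remains open. So does the effect of the acetyl and ethyl ester groups taken alone, as no pair isolates that change.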